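The compounds below may be only part of what the source reports. "The series", "measured", "known", "first", "only" and "open" are said of these compounds alone.

In an ADME assay on Huh-7 cells (Homo sapiens) for cytotoxicity, read by MTT assay, with a stated time of 72 h (on this read-out higher numbers stand for lower toxicity in this test and lower numbers for higher toxicity in this test), compound 3 `Cc1cc(=O)oc2cc(OCc3cn(-c4cccc(F)c4)nn3)ccc12` reaches only the limit of the test, > 100 ug/mL. The same limit holds for compound 1 `Cc1cc(=O)oc2cc(OCc3cn(-c4ccc(F)cc4)nn3)ccc12`, which in this assay gives > 100 ug/mL. Compound 2 `Cc1cc(=O)oc2cc(OCc3cn(-c4ccc(Cl)cc4)nn3)ccc12` likewise gives > 100 ug/mL in this assay. Because all three values sit at the limit of > 100 ug/mL in this assay, at which 3 of the 3 values shown sit, the steps between them cannot be sized: a step that the two limits leave unreadable from compound 1 to compound 3 and a step that the two limits leave unreadable from compound 2 to compound 3 are unreadable, as is a step that the two limits leave unreadable from compound 1 to compound 2. Compound 4 `COC(=O)Cn1cc(COc2ccc3c(C)cc(=O)oc3c2)nn1` differs from compound 3 by (methoxycarbonyl)methyl in place of 3-fluorophenyl on an aromatic nitrogen. Going by the values given here, none of the measured steps shows a readable change. The step of a number no higher from compound 3 to compound 4 (the limit leaves the size open) is therefore expected to stay within the scatter, with compound 4 most likely again at the limit. Compound 4 is estimated at 100 ug/mL in this assay, within 50 ug/mL to 200 ug/mL.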

Compound 4, half-maximal cytotoxic concentration: > 100 ug/mL
Compound 4: only a limit was reported (the forecaster's own chance of this, stated with the estimate: 85%); the middle value lies on the limit itself.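

No step from compound 1, compound 2 or compound 3 to compound 4 can be read, because all four stop at the same limit: the limit of > 100 ug/mL in this assay, at which 4 of the 4 values shown sit.

On these data alone, how far apart these four compounds truly lie in this assay stays open.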